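Swapping phenyl for neopentyl on the hydroxy carbon

This account rests on a few compounds, and the source may have more. Where it says the series, first, only, none or still open, it means among the compounds named here.

Compound 1, `CC(C)(C)[C@@H](O)C(=O)N1[C@@H]2C[C@@H]2C[C@H]1C(=O)NCc1cc(Cl)ccc1-n1cnnn1`: 34 10^-6 cm/s
Compound 2, `CCCC[C@@H](O)C(=O)N1N=CC[C@H]1C(=O)NCc1cc(Cl)ccc1-n1cnnn1`: 9.8 10^-6 cm/s
Compound 3, `O=C(NCc1cc(Cl)ccc1-n1cnnn1)[C@@H]1[C@H]2C[C@H]2CN1C(=O)[C@H](O)c1ccccc1`: 12 10^-6 cm/s

These three compounds were measured in an ADME assay on Caco-2 cells (Homo sapiens) for permeability, read by LC-MS, in the apical to basolateral direction, with a stated time of 60 min, at pH 6.5; a higher number here means that the compound crosses the layer faster, a lower number that the compound crosses the layer more slowly. Compound 3 sits second of the three numbers. Its nearest neighbour is compound 2, whose value lies within the usual scatter of compound 3, so no order between them can be claimed. Compound 1 stands clearly higher than compound 3, beyond the scatter.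

Compound 4, `CC(C)(C)C[C@@H](O)C(=O)N1C[C@@H]2C[C@@H]2[C@H]1C(=O)NCc1cc(Cl)ccc1-n1cnnn1`, has not been measured. It differs from compound 3 in one place: neopentyl in place of phenyl on a saturated chain carbon bound to a carbonyl carbon and an oxygen on a saturated carbon. Within the data shown here, no measured pair here shows exactly this swap, so the expectation rests on the neighbours. Because compound 1, which carries a different saturated group on that same carbon, gives 34 10^-6 cm/s, a rise above compound 3 seems plausible. Compound 4 is therefore expected to come out around 24 10^-6 cm/s, in a range from 12 10^-6 cm/s to 45 10^-6 cm/s. The expected step of a 2.0-fold higher number from compound 3 to compound 4 (0.30 log units; within the scatter) is modest and may not exceed the scatter.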

Compound 4, apparent permeability: 25 10^-6 cm/s
For compound 4 the middle estimate is 1.0-fold (0.02 log units) below the measured one; the measured number falls inside the stated range.
By their numbers in this assay, from the lowest: compounds 2 and 3 (each within the scatter of the next); then compounds 4 and 1 (each within the scatter of the next).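

Among these compounds, this is the first pair in the set that differs in only one place, so the effect of a change on this saturated chain carbon bound to a carbonyl carbon and an oxygen on a saturated carbon can now be read directly in this assay. Neopentyl in place of phenyl gives a 2.1-fold higher number from compound 3 to compound 4 (0.32 log units; beyond the scatter), so on this core the six-membered aromatic ring can leave this carbon without a fall in the number. Nothing given here explains why the number moves with this swap.

One pair cannot show whether the same swap would give a similar step on the different cores of compound 1 or compound 2. The compounds shown also leave open how cyclohexyl, a longer chain or an amine on this carbon would read in this assay.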